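The source may hold more compounds than are shown below. What is called first, only, known or untested is meant among the compounds shown, and "the series" means these compounds.

Working notes on an assay on HEK-293T cells for inhibition of diacylglycerol lipase-alpha (Homo sapiens), read by colorimetric assay (a higher number here means a weaker inhibitor, a lower number a stronger inhibitor), for this short series. Compound 1 `O=C(CCCCCCc1ccccc1)c1nncs1` returns only a limit of this assay, > 10000 nM. Compound 2 `O=C(CCCCCCc1ccccc1)c1nc(C(=O)C(F)(F)F)co1` gives 123 nM. For the measured compounds named here, compound 3 `CN(C)C(=O)c1coc(C(=O)CCCCCCc2ccccc2)n1` gives 3390 nM, the highest of the two numbers measured so far; the single step reaching it is a 28-fold higher number from compound 2 to compound 3 (1.44 log units; beyond the scatter). Compound 4 `Cc1coc(C(=O)CCCCCCc2ccccc2)n1` carries methyl in place of dimethylcarbamoyl on an aromatic carbon. Going by the values given here, no measured step covers this exact change. The nearest point of comparison is a 28-fold higher number from compound 2 to compound 3 (1.44 log units; beyond the scatter), which shows how strongly the group on this ring carbon sets the number. Compound 1 also sits at the limit of > 10000 nM in this assay, at which 1 of the 3 values shown sits. With the carbamoyl removed, no gain is expected; the expected step is a 1.8-fold higher number from compound 3 to compound 4 (0.25 log units; within the scatter). Compound 4 is estimated at 6000 nM, with a range of 1500 nM to 20000 nM in this assay.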

Compound 4, half-maximal inhibitory concentration: > 10000 nM
Compound 4 gave a limit, no number (the forecaster's own chance of this, stated with the estimate: 30%); at least 1.6-fold (0.22 log units) between middle value and limit.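

Replacing dimethylcarbamoyl with methyl on this ring carbon is not neutral: the result is an at least 2.9-fold higher number from compound 3 to compound 4 (0.46 log units; beyond the scatter). Against the (trifluoromethyl)carbonyl group, the same methyl gives an at least 81-fold higher number from compound 2 to compound 4 (1.91 log units; beyond the scatter), so among compounds 2, 3 and 4 both carbonyl-linked groups on this carbon rank ahead of methyl. Compound 4 gives only a limit, as compound 1 does, so the step between them cannot be read: the limit of > 10000 nM in this assay, at which 2 of the 4 values shown sit.

From the compounds shown here alone, whether a carboxylic acid or a methyl ester on this ring carbon would read nearer compound 2 or compound 3 stays open. Going by these compounds, the effect of a shorter chain on the core of compound 2 also stays open.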